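A few compounds are considered here, and "the series" means these few. Any claim that something is new, unique, unknown or untested is made for them only; others in the source may bear on it.

Measured so far in an in vitro assay on AV12 cells for binding affinity to Neuropeptide Y receptor type 1 (Homo sapiens); on this read-out higher numbers stand for weaker inhibition and lower numbers for stronger inhibition: compound 1 `c1ccc(OCc2nc3c(OCCCN4CCCCC4)cccc3n2CCCC2CCN(CCC3CCCCC3)CC2)cc1` at 0.285 nM; compound 2 `C=CCCN1CCC(CCCn2c(COc3ccccc3)nc3c(OCCCN4CCCCC4)cccc32)CC1` at 0.707 nM.

Within the data shown here, compound 2 holds the highest number of the two, with compound 1 the only neighbour, a 2.5-fold higher number from compound 1 to compound 2 (0.39 log units; beyond the scatter). Compound 3 `c1ccc(OCc2nc3c(OCCCN4CCCCC4)cccc3n2CCCC2CCN(CCCN3CCCCC3)CC2)cc1` differs from compound 2 by (piperidin-1-yl)methyl in place of vinyl on a saturated chain carbon, two bonds along the chain from an amine nitrogen in a ring. Among the measured compounds shown here, the single measured step that bears on this position, a 2.5-fold higher number from compound 1 to compound 2 (0.39 log units; beyond the scatter), shows that replacing vinyl with a six-membered saturated ring at this place moved the number down; the ring entering in compound 3 carries a nitrogen instead, for which no step exists. A modest downward move from compound 2 to compound 3 is expected, a 1.8-fold lower number from compound 2 to compound 3 (0.25 log units; within the scatter), giving an estimate for compound 3 of 0.4 nM, range 0.15 nM to 1.1 nM.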

Compound 3, inhibition constant: 0.106 nM
Beside the measured number, compound 3's estimate is 3.8-fold (0.58 log units) above it, outside the stated range (below it).
By their numbers in this assay, from the lowest: compound 3; then compound 1; then compound 2.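

In this assay (piperidin-1-yl)methyl at this saturated chain carbon gives a 6.7-fold lower number from compound 2 to compound 3 (0.82 log units; beyond the scatter) and so reverses the loss seen with vinyl. It also improves on cyclohexyl, with a 2.7-fold lower number from compound 1 to compound 3 (0.43 log units; beyond the scatter) at the same place, so a saturated six-membered ring alone does not set the level here: the ring bearing a nitrogen on its methyl link reads better. No supporting measurement accounts for this gain.

The compounds shown leave open whether the gain follows the ring nitrogen or the added link, which cyclohexylmethyl at this place would separate. On these data alone, how an open-chain dimethylamino group or a morpholine ring would read here also remains open.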